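Acetyl replacing hydrogen on the aryl ether of compound 2

The source may report more compounds than this note shows. Statements on the series, on what has been measured and on what is new or still open speak of the compounds shown alone.

Three members of the series carry a shared core, seen in compound 2 `O=C1OCC[C@@H]1NC(=S)SCCOc1ccccc1`, and differ only at the aromatic ring. In a functional assay on MCF7 cells (Homo sapiens) for antiproliferative activity, read by MTT assay, with a stated time of 72 h (on this read-out lower numbers stand for stronger inhibition and higher numbers for weaker inhibition), compound 2 gives > 64000 nM, which is a limit of the assay rather than a number. Compound 1 `O=C1OCC[C@@H]1NC(=S)SCCOc1ccc([N+](=O)[O-])cc1` carries a nitro group and in this assay compound 1 gives > 64000 nM, again a limit. Compound 3 `O=C1OCC[C@@H]1NC(=S)SCCOc1ccccc1[N+](=O)[O-]` carries a nitro group as well and in this assay compound 3 gives > 64000 nM, also a limit. The step that the two limits leave unreadable from compound 1 to compound 2 and the step that the two limits leave unreadable from compound 2 to compound 3 thus cannot be read, because of the limit of > 64000 nM in this assay, at which 3 of the 3 values shown sit.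

Compound 4 `CC(=O)c1ccc(OCCSC(=S)N[C@H]2CCOC2=O)cc1` follows from compound 2 by the change (acetyl in place of hydrogen on an aromatic carbon). Both nitro substitutions at the aromatic ring left compound 1 and compound 3 at the limit, so the measured steps give no readable size on which to base a direction for an acetyl group entering at the same ring. No step beyond the scatter is expected. Compound 4 is expected to give an estimated value of 70000 nM in this assay, with the expected range running from 15000 nM to 300000 nM, most probably again reported as a limit. The step from compound 2 to compound 4 is accordingly expected to be a step that the limit leaves unreadable from compound 2 to compound 4.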

Compound 4, half-maximal inhibitory concentration: > 64000 nM
Compound 4: no number, only a limit (the forecaster's own chance of this, stated with the estimate: 85%); the middle value is on the limit's open side.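

No new step can be read for compound 4 against compound 2 or compound 1, because compound 4 also gives only a limit, as do the others: the limit of > 64000 nM in this assay, at which 4 of the 4 values shown sit.

The compounds shown leave open whether any change at the aromatic ring moves a compound of this series off that limit in this assay, and by how much.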